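The source may hold more compounds than are shown below. What is called first, only, known or untested is meant among the compounds shown, and "the series" means these compounds.

Measured so far in an ADME assay on isolated protein for inhibition of Amine oxidase [flavin-containing] A (Homo sapiens), read by fluorescence and Amplex Red, with stated times of 15 min and 20 min; on this read-out higher numbers stand for weaker inhibition and lower numbers for stronger inhibition:
- compound 1 `C#CCN(CCCCOc1ccc2ccc(=O)oc2c1)Cc1cccc(OC)c1`: 78600 nM
- compound 2 `C#CCN(CCCOc1ccc2ccc(=O)oc2c1)Cc1ccc(OC)cc1`: 60000 nM
- compound 3 `C#CCN(CCCCOc1ccc2ccc(=O)oc2c1)Cc1cccc(F)c1`: 69200 nM

Compound 2 shows the lowest of the three numbers, but its distance to compound 3 and to compound 1 lies within the scatter, so no order among the three can be read from these values. Among the compounds with values here, the one step between measured compounds that differ in a single place, fluoro in place of methoxy on an aromatic carbon, runs a 1.1-fold lower number from compound 1 to compound 3 (0.06 log units; within the scatter) and is within the scatter.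

Compound 4 `C#CCN(CCCOc1ccc2ccc(=O)oc2c1)Cc1ccccc1` differs from compound 2 by hydrogen in place of methoxy on an aromatic carbon. Within the data shown here, no measured pair shows exactly this change. Among the measured compounds shown here, the only step that bears on it, a 1.1-fold lower number from compound 1 to compound 3 (0.06 log units; within the scatter), swaps the methoxy for another small group on the same ring and moves the number hardly at all; the three measured compounds, with two different benzyl substituents and two chain lengths, sit within the scatter of one another. On that basis the step of a 1.1-fold higher number from compound 2 to compound 4 (0.03 log units; within the scatter) is expected to stay within the scatter, in no particular direction. For compound 4 the estimate in this assay is 65000 nM, with a range from 30000 nM to 140000 nM.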

Compound 4, half-maximal inhibitory concentration: 38600 nM
Compound 4: middle estimate off by 1.7-fold (0.23 log units), on the high side; the range from low to high includes it.
By their numbers in this assay, from the lowest: compounds 4, 2, 3 and 1 (each within the scatter of the next, the first and the last beyond it).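

In this assay, within the data shown here, this is the first direct reading of a methoxy para to a large group: a 1.6-fold lower number from compound 2 to compound 4 (0.19 log units; within the scatter), so 4-methoxybenzyl and plain benzyl cannot be told apart here, and on this pair the methoxy makes no measurable difference at this position. Among these compounds, the only earlier step, a 1.1-fold lower number from compound 1 to compound 3 (0.06 log units; within the scatter), exchanged methoxy for fluoro in a different pair of compounds with the group elsewhere on the ring, so it could say nothing about this position or about leaving the ring position with hydrogen alone. No measurement at hand explains why the number sits where it does for either compound.

Still open, on these data alone, is whether any group at this position can move the number beyond the scatter, for instance a trifluoromethyl, a carboxylic acid or an amine in place of the methoxy. As far as these compounds go, it is equally open whether the same exchange of 4-methoxybenzyl for benzyl reads the same way on a longer chain between the core and the nitrogen.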